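Swapping Trifluoromethyl for Fluoro in Compound 1

A few compounds are considered here, and "the series" means these few. Any claim that something is new, unique, unknown or untested is made for them only; others in the source may bear on it.

Among the compounds with values here, compound 1 `C=C1C(=O)[C@]23C[C@@]1(O)CC[C@H]2c1ccc(O)c(C)c1[C@@H]3Cn1cc(-c2ccc(C(F)(F)F)cc2)nn1` is the only member of this small set for which a functional assay on A549 cells (Homo sapiens) for cytotoxicity, read by MTT assay, with a stated time of 4 days (on this read-out higher numbers stand for weaker inhibition and lower numbers for stronger inhibition), returns an actual number: in this assay compound 1 gives 1110 nM. The other two measured compounds reach only a limit of the assay. Compound 2 `C=C1C[C@]23C[C@@]1(O)CC[C@@H]2c1cccc(C)c1[C@@H]3Cn1cc(-c2ccccn2)nn1` gives > 20000 nM in this assay, which is a limit and not a number. Compound 3 `C=C1C[C@]23C[C@@]1(O)CC[C@H]2c1cc(Br)c(O)c(C)c1[C@@H]3Cn1cc(-c2ccc(OC)cc2)nn1` gives > 20000 nM in this assay, again a limit. Within the data shown here, compound 1 therefore stands apart from the limit of > 20000 nM in this assay, at which 2 of the 3 values shown sit, and no step between two measured compounds can be sized here.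

Compound 4 `C=C1C(=O)[C@]23C[C@@]1(O)CC[C@H]2c1ccc(O)c(C)c1[C@@H]3Cn1cc(-c2ccc(F)cc2)nn1` differs from compound 1 in one place: fluoro in place of trifluoromethyl on an aromatic carbon. Among the measured compounds shown here, no measured pair shows what this swap does in this assay, so any expectation rests on compound 1 alone and on the single change. A step of a 2.3-fold higher number from compound 1 to compound 4 (0.35 log units; beyond the scatter) is expected in this assay, a small shift toward weaker inhibition that may not rise beyond the usual scatter of repeated measurements. On that basis compound 4 is estimated at 2500 nM in this assay, with a range from 800 nM to 8000 nM.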

Compound 4, half-maximal inhibitory concentration: 940 nM
For compound 4 the middle estimate is 2.7-fold (0.42 log units) above the measured one; the measured number falls inside the stated range.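

Fluoro in place of trifluoromethyl on the aromatic carbon gives a 1.2-fold lower number from compound 1 to compound 4 (0.07 log units; within the scatter) in this assay, the first change in this set whose size can be read from two actual numbers. Compound 1 and compound 4 cannot be told apart on this read-out, so going from the four heavy atoms of trifluoromethyl to the single atom of fluoro, at this place on the six-membered aromatic ring, leaves the cytotoxicity reading unchanged within the usual scatter; this holds for these two groups only. Compound 2 and compound 3 each remain at a limit of the assay and not at a number: the limit of > 20000 nM in this assay, at which 2 of the 4 values shown sit.

The compounds shown leave open whether an amine, a carboxylic acid or a longer chain such as butyl at this same place would also leave the reading unchanged, or whether this place responds to a group of another kind. Compound 2 and compound 3 each differ from compound 1 in more than one place, so what sets them apart cannot be traced to any single change.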